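The source may report more compounds than this note shows. Statements on the series, on what has been measured and on what is new or still open speak of the compounds shown alone.

In a functional assay on the whole organism for inhibition, with Rattus norvegicus as the target, read by paw edema, with stated times of 1 h and 3 h (a lower number here means that less compound is needed, a higher number that more compound is needed for the effect), compound 1 (`C/C(=N\OCCCCCC(=O)O)c1ccc(Cl)cc1`) gives 92 mg/kg while compound 2 (`CCCOC(=O)CO/N=C(\C)c1ccc(Cl)cc1`) gives 14 mg/kg and compound 3 (`CNC(=O)CO/N=C(\C)c1ccc(Cl)cc1`) gives 70 mg/kg on the same read-out. Compound 3 thus lies within the usual scatter of compound 1, and both need more than compound 2. Compound 4 (`COC(=O)OCCO/N=C(\C)c1ccc(Cl)cc1`) is not yet measured. It carries ((methoxycarbonyl)oxy)methyl in place of methylcarbamoyl (((methoxycarbonyl)oxy)methyl in place of methylcarbamoyl on a saturated chain carbon bound to an oxygen on an unsaturated carbon) on the chain. Among the measured compounds shown here, the one measured step that bears on this is a 5.0-fold higher number from compound 2 to compound 3 (0.70 log units; beyond the scatter) and it is modest but beyond the scatter. Like compound 2 with its 14 mg/kg compound 4 has no methylcarbamoyl, so a lower number than for compound 3 is expected. The expected step is a 2.3-fold lower number from compound 3 to compound 4 (0.37 log units; beyond the scatter) in this assay and it should be smaller than the measured one. For compound 4 the estimated value is 30 mg/kg with 10 mg/kg to 90 mg/kg as the expected range.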

Compound 4, dose for half-maximal effect: 33 mg/kg
For compound 4 the middle estimate is 1.1-fold (0.04 log units) below the measured one; low and high end bracket the measured number.
By their numbers in this assay, from the lowest: compound 2; then compound 4; then compounds 3 and 1 (each within the scatter of the next).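

In this assay, the lower number of compound 2 is not tied to propoxycarbonyl alone: ((methoxycarbonyl)oxy)methyl in place of methylcarbamoyl also brings a drop, a 2.1-fold lower number from compound 3 to compound 4 (0.33 log units; beyond the scatter). The two groups without methylcarbamoyl are still not equivalent at this place, with a 2.4-fold higher number from compound 2 to compound 4 (0.37 log units; beyond the scatter), and the new group also improves on the chain ending in a carboxylic acid, with a 2.8-fold lower number from compound 1 to compound 4 (0.45 log units; beyond the scatter). Nothing available explains these differences. Going by these compounds, whether an amine on this chain would fall nearer compound 2 or compound 3 stays open, as does the effect of a longer chain carrying propoxycarbonyl.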